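Benzothiazole flavone ethers: deiodination with an inserted hydrazine link

The source may report more compounds than this note shows. Statements on the series, on what has been measured and on what is new or still open speak of the compounds shown alone.

Compound 1 `O=c1cc(-c2ccccc2)oc2cc(OCCCCNc3nc4ccccc4s3)cc(O)c12` and compound 2 `O=c1cc(-c2ccccc2)oc2cc(OCCCCNc3nc4ccc(I)cc4s3)cc(O)c12` share one core and differ only by a substituent on an aromatic carbon. In a physicochemical assay, read by spectrophotometry, with a stated time of 25 min (a lower number here means a stronger inhibitor, a higher number a weaker inhibitor), compound 1 gives 26.5 ug/mL, and compound 2 gives 25.4 ug/mL; the step of a 1.0-fold lower number from compound 1 to compound 2 (0.02 log units; within the scatter) stays within the scatter. Within the data shown here, compound 2 thus holds the lower of the two numbers so far, but the gap to compound 1 sets no order.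

Compound 3 `O=c1cc(-c2ccccc2)oc2cc(OCCCCNNc3nc4ccccc4s3)cc(O)c12` is not yet measured. Relative to compound 2 the change is (1,3-benzothiazol-2-yl)amino in place of 6-iodo-1,3-benzothiazol-2-yl on an amine nitrogen. Among the measured compounds shown here, only one measured step bears on it: the iodo substituent enters or leaves without a visible effect, as a 1.0-fold lower number from compound 1 to compound 2 (0.02 log units; within the scatter) shows. For the measured compounds named here, the extra chain nitrogen has no measured precedent. The step is therefore expected to be small, a 1.0-fold higher number from compound 2 to compound 3 (0.01 log units; within the scatter), with the new linker carrying the uncertainty. Compound 3 is estimated in this assay at 26 ug/mL, within a range from 13 ug/mL to 55 ug/mL.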

Compound 3, half-maximal inhibitory concentration: 24.3 ug/mL
Beside the measured number, compound 3's estimate is 1.1-fold (0.03 log units) above it; the range from low to high includes it.
By their numbers in this assay, from the lowest: compounds 3, 2 and 1 (each within the scatter of the next).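

In this assay, among these compounds, the first change at this amine nitrogen, (1,3-benzothiazol-2-yl)amino in place of 1,3-benzothiazol-2-yl, gives a 1.1-fold lower number from compound 1 to compound 3 (0.04 log units; within the scatter), so the added chain nitrogen has no readable effect here. The paired change, which also removes the iodo group, gives a 1.0-fold lower number from compound 2 to compound 3 (0.02 log units; within the scatter), so the two differences taken together also leave the number within the scatter. Nothing on hand explains why these compounds read alike, and the three compounds set no order among themselves.

On these data alone, it remains open whether this position stays this insensitive to larger changes, such as a methyl or acetyl group on the added nitrogen. A longer chain in place of the butyl link, or a carboxylic acid on the benzothiazole in place of iodo, would test the same question.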